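Same core, one swapped group: expecting compound 4

This account rests on a few compounds, and the source may have more. Where it says the series, first, only, none or still open, it means among the compounds named here.

Measured so far in a functional assay on MCF7 cells (Homo sapiens) for cytotoxicity, read by MTT assay, with a stated time of 72 h; on this read-out lower numbers stand for stronger inhibition and higher numbers for weaker inhibition:
- compound 1 `O=C(N/N=C/c1cccc(Br)c1)Nc1cc2c(Nc3ccc(F)c(Cl)c3)ncnc2cc1O[C@H]1CCOC1` gives 12400 nM
- compound 2 `COc1ccc(/C=N/NC(=O)Nc2cc3c(Nc4ccc(F)c(Cl)c4)ncnc3cc2O[C@H]2CCOC2)c(OC)c1OC` gives 33800 nM
- compound 3 `COc1cc(/C=N/NC(=O)Nc2cc3c(Nc4ccc(F)c(Cl)c4)ncnc3cc2O[C@H]2CCOC2)cc(OC)c1OC` gives 26500 nM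

Compound 3 and compound 2 lie together at the high, weaker end of these numbers, and compound 1 lies lower. The gap between the pair is small, a 1.3-fold lower number from compound 2 to compound 3 (0.11 log units; within the scatter), while a 2.1-fold higher number from compound 1 to compound 3 (0.33 log units; beyond the scatter) is a modest step.

Compared with compound 3, compound 4 `O=C(N/N=C/c1ccc(O)cc1)Nc1cc2c(Nc3ccc(F)c(Cl)c3)ncnc2cc1O[C@H]1CCOC1` has 4-hydroxyphenyl in place of 3,4,5-trimethoxyphenyl on a carbon with a double bond to nitrogen, in counted terms (4-hydroxyphenyl in place of 3,4,5-trimethoxyphenyl on a carbon with a double bond to nitrogen).

Among the measured compounds shown here, all the measured steps change a group at this same place. Besides the two above, there is a 2.7-fold higher number from compound 1 to compound 2 (0.44 log units; beyond the scatter), also modest. So swaps here have moved the number only a little. For the measured compounds named here, no measured compound carries 4-hydroxyphenyl, so the direction stays open, and only a small change is expected in this assay. The estimated step is a 1.3-fold lower number from compound 3 to compound 4 (0.12 log units; within the scatter). For compound 4 the estimated value is 20000 nM, with an expected range from 8000 nM to 50000 nM.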

Compound 4, half-maximal inhibitory concentration: 910 nM
Compound 4: middle estimate off by 22-fold (1.34 log units), on the high side, and the stated range ends above it.
By their numbers in this assay, from the lowest: compound 4; then compound 1; then compounds 3 and 2 (each within the scatter of the next).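

With 4-hydroxyphenyl on the carbon with a double bond to nitrogen, there is a 29-fold lower number from compound 3 to compound 4 (1.46 log units; beyond the scatter) and a 37-fold lower number from compound 2 to compound 4 (1.57 log units; beyond the scatter) and a 14-fold lower number from compound 1 to compound 4 (1.13 log units; beyond the scatter) in this assay so a swap at this place can move the number much further than the modest earlier steps suggested. Compared with 3,4,5-trimethoxyphenyl, the entering group has fewer heavy atoms and more hydrogen-bond donors, but these differences arrive together in a single change and cannot be separated here. No measurement at hand explains the gain.

The compounds shown leave open whether the hydroxy group itself matters or whether removing the methoxy groups is enough. Plain phenyl, 4-methoxyphenyl and 4-aminophenyl at this place would help separate those two readings.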